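Replacing a Hydroxyphenyl Group with a Methylthiophene

The source may report more compounds than this note shows. Statements on the series, on what has been measured and on what is new or still open speak of the compounds shown alone.

In a functional assay on HepG2 cells (Homo sapiens) for cytotoxicity, read by MTT assay, with a stated time of 48 h (a higher number here means a weaker inhibitor, a lower number a stronger inhibitor), compound 1 (`COc1cc(/C=C2/S/C(=N/c3ccccc3)N(Cc3ccncc3)C2=O)ccc1O`) gives 28600 nM and compound 2 (`CCOc1cc(/C=C2/S/C(=N/c3ccccc3)N(Cc3ccncc3)C2=O)ccc1O`) gives 20400 nM while compound 3 (`O=C1/C(=C\c2cccc(O)c2)S/C(=N/c2ccccc2)N1Cc1ccncc1`) gives 17600 nM on the same scale. These three values lie within the scatter of one another, so compound 3 stands level with compound 1 and compound 2.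

Compound 4 (`Cc1ccc(/C=C2/S/C(=N/c3ccccc3)N(Cc3ccncc3)C2=O)s1`) has not yet been measured. It carries 5-methylthiophen-2-yl in place of 3-hydroxyphenyl on a double-bonded chain carbon bound to a double-bonded ring carbon and shares the rest of its structure with compound 3.

Two measured changes fall at this same place. They gave a 1.6-fold lower number from compound 1 to compound 3 (0.21 log units; within the scatter) and a 1.2-fold lower number from compound 2 to compound 3 (0.06 log units; within the scatter) as their results, and both are small. A change elsewhere, methyl in place of hydrogen on a saturated chain carbon bound to an oxygen on an aromatic ring, gave a 1.4-fold lower number from compound 1 to compound 2 (0.15 log units; within the scatter) and is just as modest. Within the data shown here, no measured compound carries a five-membered aromatic ring at this place, so the expectation reaches beyond the data and its range must stay wide.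

The step expected in this assay is a 1.1-fold higher number from compound 3 to compound 4 (0.06 log units; within the scatter) and so nothing beyond the scatter in either direction. For compound 4 the estimated value is 20000 nM with an expected range from 8500 nM to 47000 nM as the likely span.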

Compound 4, half-maximal inhibitory concentration: 23100 nM
Compound 4: the middle estimate sits 1.2-fold (0.06 log units) below what was measured, within the range that was stated.
By their numbers in this assay, from the lowest: compounds 3, 2, 4 and 1 (each within the scatter of the next).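

In this assay, putting 5-methylthiophen-2-yl in place of 3-hydroxyphenyl gives a small step (a 1.3-fold higher number from compound 3 to compound 4 (0.12 log units; within the scatter)), and the same group stays just as close when it replaces 3-ethoxy-4-hydroxyphenyl (a 1.1-fold higher number from compound 2 to compound 4 (0.05 log units; within the scatter)) or 4-hydroxy-3-methoxyphenyl (a 1.2-fold lower number from compound 1 to compound 4 (0.09 log units; within the scatter)). Every earlier compound carried a six-membered aromatic ring of carbon only with a hydrogen-bond donor at this place, whereas compound 4 has a five-membered aromatic ring with a sulfur atom and no donor in this group, so among these four compounds neither the six-membered ring nor the donor is needed to keep the number at this level. No measurement here explains why the number holds through such a change.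

On these data alone, all four groups at this place are aromatic rings, and all four numbers lie within the scatter of one another, so it remains unknown whether any group here can move the number beyond the scatter. An amine or a carboxylic acid on this ring, or a saturated ring in its stead, could test how far this tolerance reaches.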